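Halogen swap on the sulfonyl ring of the tolyl analogue

A few compounds are considered here, and "the series" means these few. Any claim that something is new, unique, unknown or untested is made for them only; others in the source may bear on it.

Compound 1 `N#C/C(=C\c1ccccc1OS(=O)(=O)c1ccc(Cl)cc1)C(=O)Nc1nnc(Cc2ccccc2)s1` gives 73% in a functional assay on RS4-11 cells (Homo sapiens) for inhibition, read by CCK-8 assay, with a stated time of 48 h, tested at 20 uM; on this read-out higher numbers stand for more inhibition of growth at the one concentration tested and lower numbers for less inhibition of growth. Compound 2 `N#C/C(=C\c1ccccc1OS(=O)(=O)c1ccc(F)cc1)C(=O)Nc1nnc(Cc2ccccc2)s1` differs by fluoro in place of chloro on an aromatic carbon and gives 69% in this assay; the step is a number 4 percentage points lower from compound 1 to compound 2 (within the scatter). The core of compound 3 `Cc1ccc(Cc2nnc(NC(=O)/C(C#N)=C/c3ccccc3OS(=O)(=O)c3ccc(Cl)cc3)s2)cc1` differs from that of compound 1 by methyl in place of hydrogen on an aromatic carbon; compound 3 gives 72% in this assay, and the step is a number 1 percentage points lower from compound 1 to compound 3 (within the scatter). Compound 4 `Cc1ccc(Cc2nnc(NC(=O)/C(C#N)=C/c3ccccc3OS(=O)(=O)c3ccc(F)cc3)s2)cc1` has not yet been measured; it differs from compound 3 by fluoro in place of chloro on an aromatic carbon, the same change as from compound 1 to compound 2, at a place described in the same words. A step of a number 4 percentage points lower from compound 3 to compound 4 (within the scatter) in this assay is expected, beside the measured a number 4 percentage points lower from compound 1 to compound 2 (within the scatter), since both changes are the same and the two cores differ only by the methyl. Compound 4 is estimated at 68%, between 58% and 78%.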

Compound 4, percent growth inhibition at one concentration: 73%
Compound 4: the middle estimate sits 5 percentage points below what was measured, and the stated range covers the measured number.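

In this assay, the change from 4-chlorophenyl to 4-fluorophenyl gives a number 1 percentage points higher from compound 3 to compound 4 (within the scatter), and it compares with the earlier step as follows: the same change on two cores in this assay, a number 4 percentage points lower (within the scatter) from compound 1 to compound 2 and a number 1 percentage points higher (within the scatter) from compound 3 to compound 4, 5 percentage points apart, within the scatter of two such steps. Methyl in place of hydrogen on an aromatic carbon, read on the fluoro pair, gives a number 4 percentage points higher from compound 2 to compound 4 (within the scatter), and the comparison is similar: the same change on two cores in this assay, a number 1 percentage points lower (within the scatter) from compound 1 to compound 3 and a number 4 percentage points higher (within the scatter) from compound 2 to compound 4, 5 percentage points apart, within the scatter of two such steps. Each change therefore carries from one core to the other without a step beyond the scatter, but this does not show that either change has a real effect, and a single-concentration read-out may hide smaller differences.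

Still open, going by these compounds, is whether an amine or a carboxylic acid in place of the halogen would move the number beyond the scatter. The same applies to a longer chain in place of the methyl.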